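Methyl-substituted pyrazolopyridinone series: methoxy addition on the phenyl

The source may report more compounds than this note shows. Statements on the series, on what has been measured and on what is new or still open speak of the compounds shown alone.

Measured compounds:
compound 1, `COc1cccc(-c2cc3[nH]nc(N)c3c(=O)[nH]2)c1`, -1%
compound 2, `Cn1nc(N)c2c(=O)[nH]c(-c3ccccc3)cc21`, 6%

Both compounds were tested in an assay on isolated protein for inhibition of protein kinase C zeta type (Homo sapiens), read by mobility shift assay, tested at 30 uM; on this read-out lower numbers stand for less inhibition and higher numbers for more inhibition at the one concentration tested (going by the name of the read-out). Compound 1 gives -1%, and compound 2 gives 6%. Compound 2 holds the higher of the two numbers, but the gap to compound 1 lies within the scatter, so the two readings cannot be told apart; neither shows inhibition worth the name in this assay.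

Compound 3, `COc1cccc(-c2cc3c(c(N)nn3C)c(=O)[nH]2)c1`, is not yet measured. It differs from compound 2 by methoxy in place of hydrogen on an aromatic carbon on the aromatic carbon of the six-membered aromatic ring of carbon only, meta to a large group. For the measured compounds named here, no step between measured compounds covers this change directly; compound 1 carries the same methoxy on its phenyl ring and sits at -1%, which offers no sign that the group raises the read-out.

Given that, the step from compound 2 to compound 3 is expected to be a number 3 percentage points lower from compound 2 to compound 3 (within the scatter), that is, no movement beyond the scatter in either direction. For compound 3 the estimate in this assay is 3%, with a range from -8% to 14%.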

Compound 3, a percentage reported as inhibition, at one concentration (the size of the read-out at that concentration, not a potency): 6%
Estimate against measurement, compound 3: 3 percentage points below, and the stated range covers the measured number.
By their numbers in this assay, from the lowest: compounds 1, 2 and 3 (each within the scatter of the next).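

In this assay, for the compounds shown here, methoxy in place of hydrogen on an aromatic carbon, meta to a large group, gives no change at the digits printed from compound 2 to compound 3 (within the scatter), the first direct reading of this change, and it is made with the methyl on the aromatic nitrogen already in place. The reverse pairing, methyl in place of hydrogen on an aromatic nitrogen with the methoxy kept, gives a number 7 percentage points higher from compound 1 to compound 3 (within the scatter), so in this set of three neither single change takes the read-out beyond the scatter, whichever of the two is present. No supporting data bear on why the read-out stays flat across these changes.

Going by these compounds, all three compounds read within the scatter of each other at a single concentration, so it remains open whether this position on the phenyl ring can raise inhibition at all, or whether methoxy simply leaves the number untouched. An amine or a carboxylic acid at the same place, or a longer chain such as ethoxy, would show whether the read-out responds to anything on this ring, and a group other than methyl on the aromatic nitrogen would put the same question to that position.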